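The compounds below may be only part of what the source reports. "The series", "measured", "known", "first", "only" and "open" are said of these compounds alone.

Measured compounds:
Compound 1 `C/C(C(=O)NC1CC1)=C(/C)c1ccc(Br)cc1` gives 100 mg/kg in a toxicity assay on the whole organism (strain Icem-CET (SPF Caw)) for cytotoxicity, with Mus musculus as the target; a lower number here means that less compound is needed, a higher number that more compound is needed for the effect.
Compound 2 `C/C(C(=O)NC1CC1)=C(/C)c1ccc(Cl)cc1` gives 350 mg/kg in this assay.
Compound 3 `C#CCNC(=O)/C(C)=C(\C)c1ccc(OC)cc1` gives 150 mg/kg in this assay.

Compound 2 stands at the highest of the three numbers in this assay. Compound 3 is nearest to it, and compound 1 lies furthest from it. For the measured compounds named here, the single change recorded between measured compounds is a 3.5-fold higher number from compound 1 to compound 2 (0.54 log units; beyond the scatter), which is the only step bearing on the present question.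

Compound 4 `C/C(C(=O)NC1CC1)=C(/C)c1ccccc1` differs from compound 2 in one place: hydrogen in place of chloro on an aromatic carbon. Going by the values given here, no measured pair shows a halogen giving way to hydrogen at this position, so the expectation rests on the one halogen step alone. That step moved the number upward when the halogen was exchanged, and a further move in the same direction, modest in size or possibly within the scatter, is estimated here rather than known.

Compound 4 is therefore expected to give about 400 mg/kg in this assay, within 200 mg/kg to 900 mg/kg. The expected step from compound 2 is a 1.1-fold higher number from compound 2 to compound 4 (0.06 log units; within the scatter).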

Compound 4, dose for half-maximal effect: 100 mg/kg
The estimate for compound 4 lay 4.0-fold (0.60 log units) above the measured number; the measured number lies below the stated range.
By their numbers in this assay, from the lowest: compounds 1, 4 and 3 (each within the scatter of the next); then compound 2.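

In this assay, taking chloro off the aromatic carbon gives a 3.5-fold lower number from compound 2 to compound 4 (0.54 log units; beyond the scatter) and so reverses the step seen earlier between the two halogens. Replacing bromo with hydrogen gives no change at the digits printed from compound 1 to compound 4 (within the scatter) as the matching comparison, so bromo and hydrogen cannot be told apart at this position on the shared core. Among these three compounds, chloro alone stands apart, and the number does not follow a simple series from hydrogen through the halogens, with compound 1 going against any such trend.

Nothing available here accounts for why chloro behaves differently from bromo and hydrogen. From the compounds shown here alone, whether the higher number is specific to chloro or would also appear with fluoro, an amine or a carboxylic acid at this position remains open.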